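The source may report more compounds than this note shows. Statements on the series, on what has been measured and on what is new or still open speak of the compounds shown alone.

Compound 1 `CCCCCCNc1nc(SCc2ccc(C(F)(F)F)cc2)nc2ccccc12` gives 20200 nM in a functional assay on MDA-MB-231 cells (Homo sapiens) for cytotoxicity, read by MTT assay, with a stated time of 72 h (on this read-out lower numbers stand for stronger inhibition and higher numbers for weaker inhibition), the higher of the two plain numbers shown; compound 3 `FC(F)(F)c1ccc(CSc2nc(Nc3ccccc3)c3ccccc3n2)cc1` gives 18400 nM in this assay, a gap within the scatter. Compound 2 `CCCCCCCCCCCCNc1nc(SCc2ccc(C(F)(F)F)cc2)nc2ccccc12` yields only a limit of this assay, > 50000 nM, with the limit of > 50000 nM in this assay, at which 1 of the 3 values shown sits. Compound 4 `FC(F)(F)c1ccc(CSc2nc(Nc3ccccc3C(F)(F)F)c3ccccc3n2)cc1` differs from compound 1 by 2-(trifluoromethyl)phenyl in place of hexyl on a nitrogen on an aromatic ring. The step of a 1.1-fold lower number from compound 1 to compound 3 (0.04 log units; within the scatter) bears most directly on this change: it too replaced hexyl with an aromatic ring on that nitrogen. The step of an at least 2.4-fold higher number from compound 1 to compound 2 (0.39 log units; beyond the scatter) concerns the chain and is less relevant. A shift no larger than the scatter is therefore expected, and compound 4 is expected to give 20000 nM, between 8000 nM and 50000 nM. The expected step is a 1.0-fold lower number from compound 1 to compound 4 (0.00 log units; within the scatter).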

Compound 4, half-maximal inhibitory concentration: > 50000 nM
Compound 4: a limit, no number (the forecaster's own chance of this, stated with the estimate: 25%); middle value at least 2.5-fold (0.39 log units) away from the limit.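

On the nitrogen on an aromatic ring, swapping hexyl for an aromatic ring does not by itself decide the outcome in this assay: phenyl in compound 3 stayed within the scatter of hexyl, whereas 2-(trifluoromethyl)phenyl gives an at least 2.4-fold higher number from compound 1 to compound 4 (0.39 log units; beyond the scatter). The trifluoromethyl in place of hydrogen on an aromatic carbon is the only difference behind an at least 2.7-fold higher number from compound 3 to compound 4 (0.43 log units; beyond the scatter). Compound 4 gives only a limit, as compound 2 does: the limit of > 50000 nM in this assay, at which 2 of the 4 values shown sit.

As far as these compounds go, how far either compound lies past that limit stays unknown. From the compounds shown here alone, whether a chlorine or a methoxy group in place of that trifluoromethyl would act the same also stays open.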